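Swapping a pyridine for a hydroxyphenyl at the sulfur-linked carbon

This account rests on a few compounds, and the source may have more. Where it says the series, first, only, none or still open, it means among the compounds named here.

Compound 1 `C[C@@H](Sc1nc2c(cnn2C)c(=O)n1-c1ccccc1)c1ccccc1` gives 34 nM in an assay on isolated protein for inhibition of Retinaldehyde dehydrogenase 3 (Homo sapiens); on this read-out higher numbers stand for weaker inhibition and lower numbers for stronger inhibition.
Compound 2 `CC(Sc1nc2c(cnn2C)c(=O)n1-c1ccccc1)c1cccc(F)c1` gives 128 nM in this assay.
Compound 3 `CC(Sc1nc2c(cnn2C)c(=O)n1-c1ccccc1)c1cccnc1` gives 95 nM in this assay.

Compound 3 sits second highest of these three numbers: it is within the scatter of compound 2, and the step of a 2.8-fold higher number from compound 1 to compound 3 (0.45 log units; beyond the scatter) is the only clear gap. Compound 4 `CC(Sc1nc2c(cnn2C)c(=O)n1-c1ccccc1)c1cccc(O)c1` differs from compound 3 by 3-hydroxyphenyl in place of pyridin-3-yl on a saturated chain carbon bound to a saturated chain carbon and a sulfur. The comparable step a 1.3-fold lower number from compound 2 to compound 3 (0.13 log units; within the scatter) shows that exchanging one ring for another at this carbon barely moved the number, while a 3.8-fold higher number from compound 1 to compound 2 (0.58 log units; beyond the scatter) shows that a substituted ring here costs some potency against the plain phenyl of compound 1. Compound 4 is therefore expected to stay near compound 3, with a step of a 1.2-fold higher number from compound 3 to compound 4 (0.06 log units; within the scatter) that would not be beyond the scatter. The estimate for compound 4 is 110 nM, within 40 nM to 300 nM.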

Compound 4, half-maximal inhibitory concentration: 91 nM
Estimate against measurement, compound 4: 1.2-fold (0.08 log units) above; low and high end bracket the measured number.
By their numbers in this assay, from the lowest: compound 1; then compounds 4, 3 and 2 (each within the scatter of the next).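

Compound 4 brings a hydrogen-bond donor that pyridin-3-yl lacks, yet neither swap can be told apart from repeat measurement: 3-hydroxyphenyl for pyridin-3-yl (a 1.0-fold lower number from compound 3 to compound 4 (0.02 log units; within the scatter)) and hydroxy for fluoro (a 1.4-fold lower number from compound 2 to compound 4 (0.15 log units; within the scatter)). All three ring-bearing analogues therefore read alike, and the plain phenyl of compound 1 stays clearly apart (a 2.7-fold higher number from compound 1 to compound 4 (0.43 log units; beyond the scatter)). Nothing available explains this flat response.

Still open, on these data alone, is whether an amine or a carboxylic acid on this ring would also read alike. Also open, as far as these compounds go, is how much of the gap belongs to the ring substituent, since only compound 1 is drawn with defined handedness at this carbon.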